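The source may report more compounds than this note shows. Statements on the series, on what has been measured and on what is new or still open speak of the compounds shown alone.

In a functional assay on A549 cells (Homo sapiens) for antiproliferative activity, read by MTT assay, with a stated time of 24 h (on this read-out lower numbers stand for stronger inhibition and higher numbers for weaker inhibition), compound 1 `Cc1cccc(-n2cc(-c3cccc(NS(=O)(=O)c4c[nH]c(=O)[nH]c4=O)c3)nn2)c1` gives 3550 nM, and compound 2 `Cc1ccc(-n2cc(-c3cccc(NS(=O)(=O)c4c[nH]c(=O)[nH]c4=O)c3)nn2)cc1` gives 3630 nM. The change between them, (4-methylphenyl in place of 3-methylphenyl on an aromatic nitrogen), made the step of a 1.0-fold higher number from compound 1 to compound 2 (0.01 log units; within the scatter). Compound 3 `Cc1cccc(-n2cc(-c3ccc(NS(=O)(=O)c4c[nH]c(=O)[nH]c4=O)cc3)nn2)c1` has a different core from compound 1; the difference between the two cores is not broken down here. In this assay compound 3 gives 6960 nM. Compound 4 `Cc1ccc(-n2cc(-c3ccc(NS(=O)(=O)c4c[nH]c(=O)[nH]c4=O)cc3)nn2)cc1` has not yet been measured; it carries the same change that turned compound 1 into compound 2, namely (4-methylphenyl in place of 3-methylphenyl on an aromatic nitrogen), at a place described in the same words. Compound 4 is therefore expected to show the step of a 1.0-fold higher number from compound 3 to compound 4 (0.00 log units; within the scatter), because the matching step a 1.0-fold higher number from compound 1 to compound 2 (0.01 log units; within the scatter) lay within the scatter. Compound 4 is estimated at 7000 nM in this assay, with a range from 3500 nM to 14000 nM.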

Compound 4, half-maximal inhibitory concentration: 5560 nM
Estimate against measurement, compound 4: 1.3-fold (0.10 log units) above; the range from low to high includes it.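

In this assay the swap to 4-methylphenyl in place of 3-methylphenyl on the aromatic nitrogen gives a 1.3-fold lower number from compound 3 to compound 4 (0.10 log units; within the scatter). Set beside the same change on the core of compound 1, the two steps do not differ beyond what repeated measurements would give: the same change on two cores in this assay, a 1.0-fold higher number (0.01 log units; within the scatter) from compound 1 to compound 2 and a 1.3-fold lower number (0.10 log units; within the scatter) from compound 3 to compound 4, 1.3-fold (0.11 log units) apart, within the scatter of two such steps. This shows that on these two cores the change leaves the number within the scatter, but it does not show that the same would hold on any other core, and two small steps say little about how a larger step would carry over.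

Only methylphenyl groups stand on the aromatic nitrogen here. On these data alone, how a chlorophenyl, a methoxyphenyl or a phenyl bearing a carboxylic acid would read in this assay stays open.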